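Solubility notes on the amine-linked quinoline series: compound 4

The source may report more compounds than this note shows. Statements on the series, on what has been measured and on what is new or still open speak of the compounds shown alone.

Of the compounds shown here, three of the shared core have been measured in a physicochemical assay for solubility, with a stated time of 18 h, at pH 7.4; a higher number here means a more soluble compound, a lower number a less soluble compound. Compound 1 `COc1ccc(F)cc1CNCCCNc1ccnc2cc(Cc3ccc(C#N)cc3)ccc12` gives 4200 nM. Compound 3 `c1ccc(Cc2ccc3c(NCCCNCc4ccco4)ccnc3c2)cc1` gives 4200 nM, level with compound 1 at the digits shown and within the scatter, so no order can be drawn between these two; together they are the lowest of the three numbers. Compound 2 `COc1cccc(CNCCCNc2ccnc3cc(Oc4ccccc4)ccc23)c1O` gives 14500 nM, a step up from compound 1 beyond the scatter.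

Compound 4 `COc1ccc(F)cc1CNCCCNc1ccnc2cc(Oc3cccc(N(C)C)c3)ccc12` has not yet been measured. Against compound 1 the change is 3-(dimethylamino)phenoxy in place of 4-cyanobenzyl on an aromatic carbon. Within the data shown here, no step between measured compounds covers this change, so the expectation rests on the spread of the three values alone. A small rise is expected, toward the higher end set by compound 2 at 14500 nM, as the step of a 1.7-fold higher number from compound 1 to compound 4 (0.22 log units; within the scatter), which may not exceed the scatter. For compound 4 the expected solubility is 7000 nM, with a range from 2500 nM to 20000 nM.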

Compound 4, solubility: 14500 nM
For compound 4 the middle estimate is 2.1-fold (0.32 log units) below the measured one; the range from low to high includes it.
By their numbers in this assay, from the lowest: compounds 1 and 3 (each within the scatter of the next); then compounds 2 and 4 (each within the scatter of the next).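

In this assay, this position on the aromatic carbon now has its first readable step: 3-(dimethylamino)phenoxy in place of 4-cyanobenzyl gives a 3.5-fold higher number from compound 1 to compound 4 (0.54 log units; beyond the scatter). Among these compounds, the earlier compounds included no pair differing in one place, so this is the first sign that the read-out responds to the group here with the rest of compound 1 held fixed. Nothing available explains the step.

The change replaces the oxygen-linked ring for the carbon-linked one and the dimethylamino group for the nitrile together, so the compounds shown leave open which part carries the step. A 4-cyanophenoxy or a 3-(dimethylamino)benzyl group at the same position would separate the two, and a morpholine or a carboxylic acid on the ring would test how far the step depends on the dimethylamino group itself.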